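Adding a dimethylamino group to the methyl of compound 3

The compounds below may be only part of what the source reports. "The series", "measured", "known", "first", "only" and "open" are said of these compounds alone.

Measured compounds:
Compound 1 `O=C(O)CCc1ccc(NCc2ccc(Cl)cc2)cc1`: 111%
Compound 2 `O=C(O)CCc1ccc(NCc2ccc(-c3ccccc3)cc2)cc1`: 111%
Compound 3 `Cc1ccc(CNc2ccc(CCC(=O)O)cc2)cc1`: 152%

All three were tested in a functional assay on CHO cells for agonist activity at Free fatty acid receptor 1 (Homo sapiens), read by reporter gene assay; a lower number here means a smaller maximal response, a higher number a larger maximal response. Compound 3 gives the highest maximal response of the three; its nearest neighbour is compound 1, and compound 2 sits at the same level as compound 1, so the two lower values are within the scatter of each other.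

The next compound, compound 4 `CN(C)Cc1ccc(CNc2ccc(CCC(=O)O)cc2)cc1`, keeps the core of compound 3 and carries one change: dimethylamino in place of hydrogen on a saturated chain carbon bound to an aromatic carbon. Cut one bond further out, this reads as methyl to (dimethylamino)methyl.

The measured steps all concern the group on the aromatic carbon: a number 41 percentage points higher from compound 1 to compound 3 (beyond the scatter) and a number 41 percentage points higher from compound 2 to compound 3 (beyond the scatter), both large gains on going to methyl. Within the data shown here, no measured step adds anything onto that methyl, so these steps bear on the new change only indirectly, by showing that altering this group can move the response strongly. A step back toward the level of compound 1 and compound 2 seems as likely as no change, so a modest fall is expected, a number 27 percentage points lower from compound 3 to compound 4 (beyond the scatter). Compound 4 is therefore estimated at 125%, with a range from 95% to 155%.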

Compound 4, largest response reached (reported as percent of maximum), in percent of the reference or control that the assay uses: 12%
Beside the measured number, compound 4's estimate is 113 percentage points above it; measured number below the stated range.
By their numbers in this assay, from the lowest: compound 4; then compounds 1 and 2 (each within the scatter of the next); then compound 3.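

In this assay the methyl of compound 3 turns out not to be a place where a group can simply be added: with dimethylamino in place of hydrogen on that saturated chain carbon, the change is a number 140 percentage points lower from compound 3 to compound 4 (beyond the scatter) and takes most of the response away. The earlier swaps among chloro, phenyl and methyl moved the response only upward or not at all, whereas (dimethylamino)methyl gives a number 99 percentage points lower from compound 2 to compound 4 (beyond the scatter) and likewise a number 99 percentage points lower from compound 1 to compound 4 (beyond the scatter) in the same assay. A change at this place can therefore push the response far under the level of all three earlier compounds. No measurement at hand accounts for this fall.

The compounds shown leave open whether the loss follows the amine itself or any group added onto that methyl. An ethyl or methoxymethyl group here, set against an aminomethyl group, would separate these two readings.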